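The source may report more compounds than this note shows. Statements on the series, on what has been measured and on what is new or still open speak of the compounds shown alone.

The measured compounds:

- compound 1, `NC(=O)c1c(NC(=O)c2ccccc2Br)sc2c1CCN(C(=S)Nc1ccccc1Cl)C2`; in a functional assay on HeLa cells (Homo sapiens) for antiproliferative activity, with a stated time of 24 h (on this read-out lower numbers stand for stronger inhibition and higher numbers for weaker inhibition), compound 1 gives 46900 nM
- compound 2, `NC(=O)c1c(NC(=O)c2ccccc2Br)sc2c1CCN(C(=S)Nc1ccccc1Br)C2`; compound 2 gives 24700 nM
- compound 3, `Cc1ccccc1NC(=S)N1CCc2c(sc(NC(=O)c3ccccc3Br)c2C(N)=O)C1`; compound 3 gives > 50000 nM, which is a limit of the assay and not a number

Compound 3 therefore stands at the limit of > 50000 nM in this assay, at which 1 of the 3 values shown sits, so for it only this floor is known and no exact value.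

Compound 4, `Cc1ccccc1NC(=S)N1CCc2c(sc(NC(=O)c3ccccc3C(F)(F)F)c2C(N)=O)C1`, differs from compound 3 in one place: trifluoromethyl in place of bromo on an aromatic carbon. Among the compounds with values here, none of the measured steps touches this same position, but each of them likewise exchanges one small group on an aromatic carbon for another. The step of a 1.9-fold lower number from compound 1 to compound 2 (0.28 log units; within the scatter) stayed within the scatter. The steps of an at least 1.0-fold higher number from compound 1 to compound 3 (0.02 log units; that floor lies within the scatter) and an at least 2.0-fold higher number from compound 2 to compound 3 (0.30 log units; that floor lies within the scatter) each end at a limit, and their floors also lie within the scatter. Across these three compounds, swapping one small aromatic substituent for another has not produced a step beyond the scatter, so for compound 4 no movement beyond the scatter is expected either, in either direction.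

Compound 4 is accordingly expected to give about 50000 nM, within a range from 25000 nM to 100000 nM, with a fair chance that the assay again reports only a limit. This expectation corresponds to a number no higher from compound 3 to compound 4 (the limit leaves the size open).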

Compound 4, half-maximal inhibitory concentration: 47000 nM
Beside the measured number, compound 4's estimate is 1.1-fold (0.03 log units) above it; low and high end bracket the measured number.
By their numbers in this assay, from the lowest: compounds 2, 1 and 4 (each within the scatter of the next). At a limit, above all of these: compound 3.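

Within the data shown here, the earlier steps all changed a different position, so this is the first look at the 2-bromophenyl group, and the change to 2-(trifluoromethyl)phenyl gives an at least 1.0-fold lower number from compound 3 to compound 4 (0.02 log units; that floor lies within the scatter) in this assay. Here a trifluoromethyl group of 4 heavy atoms takes the place of a bromo group of 1 heavy atom, ortho to a large group, and compound 4 gives a true reading of 47000 nM. The printed floor of the step does not show a gain beyond the scatter. The real size of the step stays unknown because compound 3 has no exact value, only a limit of the assay and not a number: the limit of > 50000 nM in this assay, at which 1 of the 4 values shown sits.

Going by these compounds, only bromo and trifluoromethyl appear at this position, so it remains open whether an amine, a carboxylic acid or a longer chain there would shift the number clearly in either direction. On these data alone, it also remains open whether the trifluoromethyl group would behave the same way if the methyl group of compound 4 were replaced by the chloro of compound 1 or the bromo of compound 2.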